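The compounds below may be only part of what the source reports. "The series", "measured", "known", "first", "only" and "open" are said of these compounds alone.

Series notes. In an ADME assay on microsomes from liver (Homo sapiens) for metabolic stability, read by HPLC, with a stated time of 10 min, tested at 3 uM (a higher number here means that more of the compound is left, a lower number that less of the compound is left), compound 1 `COC[C@H](C1CC1)n1cc(Cl)nc(Nc2cc(C)c(OC)nc2C)c1=O` gives 48%. Compound 2 `COC[C@@H](C1CC1)n1cc(Cl)nc(Nc2cc(C)c(OC)nc2C)c1=O` differs from compound 1 only in the configuration as drawn; in this assay compound 2 gives 40%. The step is a number 8 percentage points lower from compound 1 to compound 2 (within the scatter), which may be read against (the fact that compounds 1 and 2 differ only in the configuration as drawn). Compound 3 `CC[C@H](C1CC1)n1cc(Cl)nc(Nc2cc(C)c(OC)nc2C)c1=O` gives 51% in this assay. The steps to compound 3 are a number 3 percentage points higher from compound 1 to compound 3 (within the scatter) and a number 11 percentage points higher from compound 2 to compound 3 (beyond the scatter). On the numbers in hand compound 3 has the highest value of the three, though its gap to compound 1 lies within the scatter and only the gap to compound 2 lies beyond it.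

Compound 4 `CC[C@H](C1CC1)n1cc(C#N)nc(Nc2cc(C)c(OC)nc2C)c1=O` is the next member. Its change from compound 3 is cyano in place of chloro on an aromatic carbon. Among the compounds with values here, none of the measured steps touches this position: the three steps known concern the group on the aromatic nitrogen or the configuration as drawn, and all of them stayed within or barely beyond the scatter. There is therefore no measured basis for a step beyond the scatter in either direction in this assay; the expected step is a number 1 percentage points lower from compound 3 to compound 4 (within the scatter), essentially none. Compound 4 is accordingly estimated at 50% in this assay, with a range from 35% to 65%.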

Compound 4, percent of the compound remaining: 81%
For compound 4 the middle estimate is 31 percentage points below the measured one; measured number outside the range, above it.
By their numbers in this assay, from the lowest: compounds 2, 1 and 3 (each within the scatter of the next, the first and the last beyond it); then compound 4.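

In this assay the aromatic carbon next to the ring nitrogen proves to be a place where one exchange moves the number far more than the earlier changes did: cyano in place of chloro gives a number 30 percentage points higher from compound 3 to compound 4 (beyond the scatter), whereas the largest earlier step, at the group on the aromatic nitrogen, is a number 11 percentage points higher from compound 2 to compound 3 (beyond the scatter). The earlier compounds shown here all carry chloro at this carbon, so they showed only how the group on the aromatic nitrogen and the configuration as drawn read, and gave no view of this position. What is known about compounds 1 and 2 concerns configuration alone and does not bear on this exchange.

As far as these compounds go, the cyano reading rests on a single pair with the 1-cyclopropylpropyl group in place, so it remains open whether the 1-cyclopropyl-2-methoxyethyl group, in either configuration as drawn, would give a step of similar size with cyano at this carbon. Also open is how a methyl, a trifluoromethyl or a primary amide on this carbon would read in this assay, as the compounds shown hold only chloro and cyano there.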